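Carboxyphenyl in Place of Aminophenyl: Expected Loss of Potency

The source may report more compounds than this note shows. Statements on the series, on what has been measured and on what is new or still open speak of the compounds shown alone.

Measured in a functional assay on SK-OV-3 cells (Homo sapiens) for inhibition, read by CCK-8 assay, with a stated time of 70 h; on this read-out higher numbers stand for weaker inhibition and lower numbers for stronger inhibition:
- compound 1 `O=[N+]([O-])c1ccc(COc2ccc(OCCOCCNC3CCCC3)cc2)cc1`: 20300 nM
- compound 2 `O=C(O)c1ccccc1COc1ccc(OCCOCCNC2CCCC2)cc1`: > 100000 nM
- compound 3 `Nc1ccccc1COc1ccc(OCCOCCNC2CCCC2)cc1`: 14000 nM

The value of compound 2 is a limit of the assay, not a number. Among the two numbers shown, compound 3 has the lowest, and compound 1 is its nearest with a 1.5-fold lower number from compound 1 to compound 3 (0.16 log units; within the scatter), so the two cannot be told apart.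

Compound 4 `O=C(O)c1ccc(COc2ccc(OCCOCCNC3CCCC3)cc2)cc1` differs from compound 3 in one place: 4-carboxyphenyl in place of 2-aminophenyl on a saturated chain carbon bound to an oxygen on an aromatic ring. Among the compounds with values here, two measured steps bear on this. Replacing an amino group with a carboxy group in the reverse direction gave an at least 7.1-fold lower number from compound 2 to compound 3 (0.85 log units; beyond the scatter), and swapping a 4-nitrophenyl for a 2-carboxyphenyl gave an at least 4.9-fold higher number from compound 1 to compound 2 (0.69 log units; beyond the scatter), both resting on (the limit of > 100000 nM in this assay, at which 1 of the 3 values shown sits). In compound 2 the carboxy group sits as 2-carboxyphenyl, whereas in compound 4 it stands as 4-carboxyphenyl, so the comparison is not exact. Still, a clearly higher number is expected in this assay, with a good chance that only a limit is reported, and the step from compound 3 to compound 4 is estimated as a 7.1-fold higher number from compound 3 to compound 4 (0.85 log units; beyond the scatter). Compound 4 is therefore expected to give 100000 nM, with a range from 30000 nM to 300000 nM.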

Compound 4, half-maximal inhibitory concentration: > 100000 nM
Compound 4: a limit, no number (the forecaster's own chance of this, stated with the estimate: 55%); the middle value lies on the limit itself.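

In this assay compound 4 gives > 100000 nM, which is a limit and not a number. Until now the carboxy group had been seen only as 2-carboxyphenyl, whereas 4-carboxyphenyl now gives an at least 7.1-fold higher number from compound 3 to compound 4 (0.85 log units; beyond the scatter), and carboxy in place of nitro on an aromatic carbon, with the group name otherwise unchanged at the 4-phenyl, gives an at least 4.9-fold higher number from compound 1 to compound 4 (0.69 log units; beyond the scatter). In these compounds, then, the weaker result goes with both carboxyphenyl groups and is not tied to only one of them.

The step from compound 2 to compound 4 cannot be read, as both values are limits: the limit of > 100000 nM in this assay, at which 2 of the 4 values shown sit.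

Also open, as far as these compounds go, is whether a methyl ester or a primary amide in place of the carboxy group, or a 4-aminophenyl group, would give a number close to that of compound 3.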